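The compounds below may be only part of what the source reports. "The series", "measured", "known", "first", "only" and "open" are said of these compounds alone.

Measured so far in a functional assay on OVCAR-5 cells (Homo sapiens) for inhibition, read by colorimetric assay and sulforhodamine B assay, with a stated time of 48 h; on this read-out higher numbers stand for weaker inhibition of growth and lower numbers for stronger inhibition of growth:
- Compound 1 `CCCCCCCCCCCC[C@@H](O)[C@H]1CC[C@H]([C@H](O)CCCCCCCCCCNC(=O)c2cccs2)O1`: 2510 nM
- Compound 2 `CCCCCCCCCCCC[C@@H](O)[C@H]1CC[C@H]([C@H](O)CCCCCCCCCCNC(=O)c2ccco2)O1`: 100000 nM

Compound 2 holds the higher of these two numbers, which makes it the weaker growth inhibitor of the pair. Compound 3 `CCCCCCCCCCCC[C@@H](O)[C@H]1CC[C@H]([C@H](O)CCCCCCCCCCNC(=O)c2ccnn2C)O1` has not been measured yet and differs from compound 2 in one place: 1-methyl-1H-pyrazol-5-yl in place of furan-2-yl on a carbonyl carbon. In words, 1-methyl-1H-pyrazol-5-yl takes the place of furan-2-yl on a carbonyl carbon, and the rest of the molecule stays the same.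

Going by the values given here, only one measured step bears on this change, and it sits at the same place: a 40-fold higher number from compound 1 to compound 2 (1.60 log units; beyond the scatter). This large step shows that exchanging the group on this carbonyl carbon can shift the number strongly in this assay. It does not settle the direction for a group that neither measured compound carries. Among the compounds with values here, with compound 2 at 100000 nM as the higher of only two values, a lower number seems the more likely outcome, though little or no change remains possible.

The expected change is a 5.0-fold lower number from compound 2 to compound 3 (0.70 log units; beyond the scatter) as a rough estimate. For compound 3 the estimated value is 20000 nM, with an expected range from 4000 nM to 100000 nM as its limits.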

Compound 3, concentration for 50% growth inhibition: 100000 nM
Compound 3: middle estimate off by 5.0-fold (0.70 log units), on the low side, within the range that was stated.
By their numbers in this assay, from the lowest: compound 1; then compounds 2 and 3 (each within the scatter of the next).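

In this assay, replacing furan-2-yl with 1-methyl-1H-pyrazol-5-yl on the carbonyl carbon gives no change at the digits printed from compound 2 to compound 3 (within the scatter), so these two groups cannot be told apart in this test, even though their rings carry different hetero atoms and the new group has a methyl on its ring. Measured against thiophen-2-yl, the new group gives a 40-fold higher number from compound 1 to compound 3 (1.60 log units; beyond the scatter), a step of the same size as a 40-fold higher number from compound 1 to compound 2 (1.60 log units; beyond the scatter). The large loss is therefore not peculiar to furan-2-yl, as it now appears with two different replacements for thiophen-2-yl, and of the three groups shown, only thiophen-2-yl goes with the lower number.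

The data offer no explanation for why thiophen-2-yl stands apart from the other two groups. The compounds shown also leave open how other groups on this carbonyl carbon would behave, such as thiophen-3-yl, a plain phenyl ring or a thiophen-2-yl ring carrying a chlorine, and so whether the lower number belongs to thiophen-2-yl alone or extends to close relatives.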